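Trifluoromethylphenyl for methylphenyl on a spirooxindole triazole

The compounds below may be only part of what the source reports. "The series", "measured", "known", "first", "only" and "open" are said of these compounds alone.

Compound 1 `N#CC1=C(N)Oc2c(c3nc4ccccc4nc3c3ccccc23)C12C(=O)N(Cc1cnnn1-c1ccc(Br)cc1)c1ccccc12`: in an ADME assay on L02 cells (Homo sapiens) for antiproliferative activity, read by MTT assay, with a stated time of 48 h (on this read-out higher numbers stand for weaker inhibition and lower numbers for stronger inhibition), compound 1 gives > 50000 nM, which is a limit of the assay and not a number.
Compound 2 `Cc1ccccc1-n1nncc1CN1C(=O)C2(C(C#N)=C(N)Oc3c(N)cc4nc5ccccc5nc4c32)c2ccccc21`: in this assay compound 2 gives > 50000 nM, again a limit rather than a number.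

Compound 2 therefore stands at the edge of what this assay can report, and the two values shown sit together there (the limit of > 50000 nM in this assay, at which 2 of the 2 values shown sit). Going by the values given here, no step between measured compounds is available.

Compound 3 `N#CC1=C(N)Oc2c(N)cc3nc4ccccc4nc3c2C12C(=O)N(Cc1cnnn1-c1cccc(C(F)(F)F)c1)c1ccccc12` differs from compound 2 by a single change (3-(trifluoromethyl)phenyl in place of 2-methylphenyl on an aromatic nitrogen).

With both measured compounds at the same limit, no step beyond the scatter is expected, and the expected step from compound 2 to compound 3 in this assay is a step that the limit leaves unreadable from compound 2 to compound 3. Compound 3 is estimated at 60000 nM, within a range from 30000 nM to 150000 nM, and most likely the assay will again report only a limit.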

Compound 3, half-maximal inhibitory concentration: 38100 nM
Compound 3: the middle estimate sits 1.6-fold (0.20 log units) above what was measured; low and high end bracket the measured number.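

Among the compounds shown, compound 3 is the only one for which this assay returns a number rather than a limit, so a change on this aromatic nitrogen can bring a reading inside the range the assay reports. Placing 3-(trifluoromethyl)phenyl there instead of 2-methylphenyl gives an at least 1.3-fold lower number from compound 2 to compound 3 (0.11 log units; that floor lies within the scatter), and this floor alone does not establish a real difference between the two compounds. The true size of the step cannot be read because compound 2 gives only a limit: the limit of > 50000 nM in this assay, at which 2 of the 3 values shown sit.

Going by these compounds, whether the reading depends on the trifluoromethyl group itself or on where it sits on the phenyl ring remains open. Also open, on these data alone, is how an amine or a carboxylic acid on that phenyl ring would read in this assay.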